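The source may hold more compounds than are shown below. What is called first, only, known or untested is meant among the compounds shown, and "the series" means these compounds.

Measured so far:
compound 1 `O=C(NO)c1ccc(NCc2nc(-c3cccc4cnccc34)nn2-c2ccccc2)cc1` — 40.2%
compound 2 `O=C(NO)c1ccc(NCc2nc(-c3cccc(Cl)c3)nn2-c2ccccc2)cc1` — 61.2%
compound 3 `O=C(NO)c1ccc(NCc2nc(-c3ccc(Cl)c(Cl)c3)nn2-c2ccccc2)cc1` — 34.5%

In an assay on Sf9 cells for inhibition of protein deacetylase HDAC6 (Homo sapiens), read by fluorescence, with a stated time of 40 min, tested at 100 nM (a lower number here means less inhibition, a higher number more inhibition at the concentration tested (going by the name of the read-out)), compound 3 stands lowest of the three numbers; compound 1 sits within the scatter of it, compound 2 beyond it. Compound 4 `Cc1cccc(-c2nc(CNc3ccc(C(=O)NO)cc3)n(-c3ccccc3)n2)c1` arises from compound 3 by 3-methylphenyl in place of 3,4-dichlorophenyl on an aromatic carbon. The step that bears on this is a number 26.7 percentage points lower from compound 2 to compound 3 (beyond the scatter), which went in the opposite direction: compound 4 again carries a single substituent on that ring, as compound 2 does. Within the data shown here, no measured pair compares methyl with chloro, so the size of the expected rise is uncertain. Compound 4 is expected to give 52% (range 32% to 70%). The estimated step is therefore a number 17.5 percentage points higher from compound 3 to compound 4 (beyond the scatter), a rise beyond the scatter toward compound 2.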

Compound 4, a percentage reported as inhibition, at one concentration (the size of the read-out at that concentration, not a potency): 64.1%
Compound 4: middle estimate off by 12.1 percentage points, on the low side; low and high end bracket the measured number.
By their numbers in this assay, from the lowest: compounds 3 and 1 (each within the scatter of the next); then compounds 2 and 4 (each within the scatter of the next).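

In this assay the change gives a number 29.6 percentage points higher from compound 3 to compound 4 (beyond the scatter) and the replacement of isoquinolin-5-yl gives a number 23.9 percentage points higher from compound 1 to compound 4 (beyond the scatter). Methyl in place of chloro gives a number 2.9 percentage points higher from compound 2 to compound 4 (within the scatter), so 3-methylphenyl and 3-chlorophenyl cannot be told apart at this position, and the higher number does not depend on chloro. Nothing shown accounts for these differences. On these data alone, whether a phenyl ring carrying an amine or a carboxylic acid in place of methyl keeps this level remains open. As far as these compounds go, the values at concentrations other than the one tested also remain open.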